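The source may report more compounds than this note shows. Statements on the series, on what has been measured and on what is new or still open speak of the compounds shown alone.

Within the series compound 3 `CCCCCC#Cc1cn([C@H]2C[C@H](O)[C@@H](CO)O2)c(=O)[nH]c1=O` stands at the lowest of the two numbers in a functional assay on L1210 cells (Mus musculus) (a lower number here means a stronger inhibitor, a higher number a weaker inhibitor), giving 219 ug/mL; compound 1 `CCCCC#Cc1cn([C@H]2C[C@H](O)[C@@H](CO)O2)c(=O)[nH]c1=O` gives 1000 ug/mL, with a 4.6-fold lower number from compound 1 to compound 3 (0.66 log units; beyond the scatter). Compound 2 `O=c1[nH]c(=O)n([C@H]2C[C@H](O)[C@@H](CO)O2)cc1C#CCCO` reaches only a limit of this assay, > 1000 ug/mL, as shown by the limit of > 1000 ug/mL in this assay, at which 1 of the 3 values shown sits. Compound 4 `O=c1[nH]c(=O)n([C@H]2C[C@H](O)[C@@H](CO)O2)cc1C#CCCCO` differs from compound 3 by hydroxy in place of ethyl on a saturated chain carbon, three bonds along the chain from a triple-bonded carbon. The same exchange, made on a saturated chain carbon two bonds along the chain from a triple-bonded carbon, gave a number no lower from compound 1 to compound 2 (the limit leaves the size open), and the opposite exchange at that place gave an at least 4.5-fold lower number from compound 2 to compound 3 (0.65 log units; beyond the scatter). A weakening in this assay is therefore expected for compound 4, probably up to the limit again, amounting to a 4.6-fold higher number from compound 3 to compound 4 (0.66 log units; beyond the scatter). Compound 4 is estimated at 1000 ug/mL, with a range from 400 ug/mL to 3000 ug/mL.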

Compound 4, concentration for 50% inhibition: 280 ug/mL
The estimate for compound 4 lay 3.6-fold (0.55 log units) above the measured number; measured number below the stated range.
By their numbers in this assay, from the lowest: compounds 3 and 4 (each within the scatter of the next); then compound 1.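

In this assay, hydroxy in place of ethyl on a saturated chain carbon, three bonds along the chain from a triple-bonded carbon, gives no step beyond the scatter, with a 1.3-fold higher number from compound 3 to compound 4 (0.11 log units; within the scatter). A terminal hydroxy therefore does not by itself bring a number to the limit of the assay. Compound 4 also reads stronger than both neighbours, with an at least 3.5-fold lower number from compound 2 to compound 4 (0.55 log units; beyond the scatter) and a 3.6-fold lower number from compound 1 to compound 4 (0.55 log units; beyond the scatter).

Going by these compounds, whether the exchange truly differs between the two chain places stays open: the same change on two cores in this assay, a number no lower (the limit leaves the size open) from compound 1 to compound 2 and a 1.3-fold higher number (0.11 log units; within the scatter) from compound 3 to compound 4; the limit leaves it open whether they differ How an amine or a carboxylic acid would read at this place also stays open.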